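Removing the amide methyl in a quinolinone Substance-P antagonist series

A few compounds are considered here, and "the series" means these few. Any claim that something is new, unique, unknown or untested is made for them only; others in the source may bear on it.

Measured compounds:
compound 1 `Cn1c(COCc2cc(C(F)(F)F)cc(C(F)(F)F)c2)c(-c2ccccc2)c2ccccc2c1=O` gives 23 nM in an assay on IM-9 cells for binding affinity to Substance-P receptor (Homo sapiens); on this read-out higher numbers stand for weaker inhibition and lower numbers for stronger inhibition
compound 2 `Cc1ccccc1-c1c(C(=O)N(C)Cc2cc(C(F)(F)F)cc(C(F)(F)F)c2)n(C)c(=O)c2ccccc12` gives 1.3 nM in this assay
compound 3 `CN(Cc1cc(C(F)(F)F)cc(C(F)(F)F)c1)C(=O)c1c(-c2ccccc2)c2ccccc2c(=O)n1C` gives 1.2 nM in this assay

Compound 2 stands second highest of the three numbers; compound 3 sits a 1.1-fold lower number from compound 2 to compound 3 (0.03 log units; within the scatter) from it, while compound 1 gives a higher number, a gap beyond the scatter, although the two differ in more than one place, so only their two values can be compared.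

Compound 4 `Cc1ccccc1-c1c(C(=O)NCc2cc(C(F)(F)F)cc(C(F)(F)F)c2)n(C)c(=O)c2ccccc12` differs from compound 2 by hydrogen in place of methyl on an amide-type nitrogen. Within the data shown here, the only measured single step, from compound 2 to compound 3, changed a methyl on an aromatic carbon, not on the amide-type nitrogen, and it stayed within the scatter; no measured step touches the amide-type nitrogen itself. The expectation therefore rests on little, and a weaker binding is expected, with a 12-fold higher number from compound 2 to compound 4 (1.06 log units; beyond the scatter). Compound 4 is expected to give 15 nM, within 3 nM to 100 nM.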

Compound 4, half-maximal inhibitory concentration: 2.5 nM
Estimate against measurement, compound 4: 6.0-fold (0.78 log units) above, and the stated range ends above it.
By their numbers in this assay, from the lowest: compounds 3, 2 and 4 (each within the scatter of the next, the first and the last beyond it); then compound 1.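

In this assay, putting hydrogen in place of methyl on the amide-type nitrogen gives a 1.9-fold higher number from compound 2 to compound 4 (0.28 log units; within the scatter), so compound 2 and compound 4 cannot be told apart on this read-out. Among these compounds, this is the first measured step at this nitrogen, and it shows that, in this pair, the methyl there is not needed to keep the number in the same low range, and that a compound carrying the amide hydrogen binds on a par with its methylated partner. Nothing shown here offers a measured explanation for this result.

From the compounds shown here alone, it remains open whether the same swap would give a similar result on compound 3, which lacks the methyl on the aromatic carbon. Going by these compounds, the effect of an ethyl group, a longer chain or a chain ending in an amine on this nitrogen also remains open.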